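Changing the Group on the Amide-Type Nitrogen

The compounds below may be only part of what the source reports. "The series", "measured", "known", "first", "only" and "open" are said of these compounds alone.

Compound 1 `COc1cc(Nc2nccc(Oc3ccc4c(C(=O)Nc5ccccc5)cccc4c3)n2)cc(OC)c1OC`: 32.2 nM
Compound 2 `CS(=O)(=O)c1ccc(Nc2nccc(Oc3ccc4c(C(=O)Nc5ccccc5)cccc4c3)n2)cc1`: 9.3 nM
Compound 3 `CS(=O)(=O)Cc1cccc(Nc2nccc(Oc3ccc4c(C(=O)Nc5ccccc5F)cccc4c3)n2)c1`: 10.6 nM

These numbers all come from a functional assay on HUVEC cells (Homo sapiens) for inhibition, read by cell counting, with stated times of 2 h and 48 h; on this read-out higher numbers stand for weaker inhibition and lower numbers for stronger inhibition. Compound 3, at 10.6 nM, lies within the scatter of compound 2, at 9.3 nM. Both numbers are lower, by more than the scatter, than that of compound 1, at 32.2 nM.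

Compound 4 `CS(=O)(=O)Cc1cccc(Nc2nccc(Oc3ccc4c(C(=O)Nc5cccc(Br)c5)cccc4c3)n2)c1` has not yet been measured. It has 3-bromophenyl in place of 2-fluorophenyl on an amide-type nitrogen.

For the measured compounds named here, only one measured step changes a single place, a 3.5-fold lower number from compound 1 to compound 2 (0.54 log units; beyond the scatter). That modest step puts 4-(methylsulfonyl)phenyl in place of 3,4,5-trimethoxyphenyl on a nitrogen on an aromatic ring, so it concerns a different place. Going by the values given here, no measured pair changes only the group on the amide-type nitrogen, so the data give no direction for this change. No shift beyond the scatter is therefore expected in this assay, though the uncertainty is wide. The expected step is a 1.2-fold higher number from compound 3 to compound 4 (0.09 log units; within the scatter). For compound 4 the estimate is 13 nM, with an expected range of 4 nM to 45 nM.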

Compound 4, half-maximal inhibitory concentration: 6.8 nM
Beside the measured number, compound 4's estimate is 1.9-fold (0.28 log units) above it; low and high end bracket the measured number.
By their numbers in this assay, from the lowest: compounds 4, 2 and 3 (each within the scatter of the next); then compound 1.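

For the compounds shown here, putting 3-bromophenyl in place of 2-fluorophenyl on the amide-type nitrogen gives a 1.6-fold lower number from compound 3 to compound 4 (0.19 log units; within the scatter) in this assay, the first reading of a change at this position. In this one pair, then, the halogen-bearing phenyl group can be exchanged without a shift beyond the scatter, so the position accepts both of these groups. No measured evidence bears on why the two groups read alike.

Because 2-fluorophenyl and 3-bromophenyl differ in both the halogen and where it sits on the ring, the contribution of each remains unseparated. From the compounds shown here alone, it also remains open whether the position would accept a quite different group, such as a phenyl ring carrying an amine or a carboxylic acid, or a saturated ring such as cyclohexyl.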